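Swapping a chloro for a methyl on compound 3

This account rests on a few compounds, and the source may have more. Where it says the series, first, only, none or still open, it means among the compounds named here.

Measured so far in a functional assay on K562 cells (Homo sapiens) for inhibition, read by trypan blue exclusion, with a stated time of 48 h (on this read-out higher numbers stand for weaker inhibition and lower numbers for stronger inhibition), for three compounds:
- compound 1 `NC(=O)c1cc(Cl)ccc1NC(=O)/C=C/c1cccc(Br)c1` gives > 10000 nM (a limit)
- compound 2 `Cc1cccc(/C=C/C(=O)Nc2ccc(Cl)cc2C(N)=O)c1` gives > 10000 nM (a limit)
- compound 3 `NC(=O)c1cc(Br)ccc1NC(=O)/C=C/c1ccccc1Cl` gives 8100 nM (a number)

Going by the values given here, compound 3 is the only compound with a true number at 8100 nM in this assay and so it is the single fixed point here. The rest of the picture is the limit of > 10000 nM in this assay, at which 2 of the 3 values shown sit, and such a limit is not a number.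

The next compound, compound 4 `Cc1ccccc1/C=C/C(=O)Nc1ccc(Br)cc1C(N)=O`, is still unmeasured and differs from compound 3 in one place: methyl in place of chloro on an aromatic carbon and this is methyl in place of chloro on an aromatic carbon, ortho to a large group.

Among the compounds with values here, the one measured step that brings in a methyl is a step that the two limits leave unreadable from compound 1 to compound 2 with a bromo leaving rather than a chloro, so it offers no size to carry over. With no measured size to lean on, no shift beyond the scatter is expected in this assay and no direction can be favoured, so the expected change is a 1.1-fold higher number from compound 3 to compound 4 (0.05 log units; within the scatter) for now. For compound 4 the estimated value is 9000 nM with an expected range from 4000 nM to 20000 nM and a report of only a limit would be no surprise.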

Compound 4, half-maximal inhibitory concentration: > 10000 nM
Compound 4: a limit, no number (the forecaster's own chance of this, stated with the estimate: 50%); middle value at least 1.1-fold (0.04 log units) away from the limit.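

In this assay, going by these compounds alone, the change from 2-chlorophenyl to 2-methylphenyl gives an at least 1.2-fold higher number from compound 3 to compound 4 (0.09 log units; that floor lies within the scatter) as the first step that can be read at all, though only as a floor and not as a size. Compound 4 gives > 10000 nM as a limit and not a number, so at this place, ortho to a large group, methyl in place of chloro shows no gain in inhibition, while any loss beyond the scatter cannot be told from this result. Within the data shown here, the one earlier step that brought in a methyl, from compound 1 to compound 2, cannot be read and gave not even a floor, and the series now rests mostly on limits: the limit of > 10000 nM in this assay, at which 3 of the 4 values shown sit.

As far as these compounds go, how far compound 4 lies beyond its limit remains open, and with it the true size of this step. Also open, from the compounds shown here alone, is what an amine or a carboxylic acid on this same aromatic carbon would do to the number, and whether any group there can bring the value lower than the chloro of compound 3 does.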